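The source may hold more compounds than are shown below. What is called first, only, known or untested is meant among the compounds shown, and "the series" means these compounds.

Compound 2 `COc1ccc(-n2nc(C(=O)Nc3cccc(F)c3)nc2-c2cc(OC)c(OC)c(OC)c2)cc1` gives 72% in a functional assay on the whole organism for inhibition, with Rattus norvegicus as the target, read by paw edema, with stated times of 30 min and 3 h, at a dose of 0.28 mmol/kg by the oral route (on this read-out higher numbers stand for more inhibition at the one dose given (going by the name of the read-out) and lower numbers for less inhibition), and compound 1 `COc1ccc(-n2nc(C(N)=O)nc2-c2cc(OC)c(OC)c(OC)c2)cc1` gives 72%; the two stand level, as no change at the digits printed from compound 1 to compound 2 (within the scatter) shows. Compound 3 `COc1ccc(-n2nc(C(=O)Nc3ccc(O)cc3)nc2-c2cc(OC)c(OC)c(OC)c2)cc1` differs from compound 2 in one place: 4-hydroxyphenyl in place of 3-fluorophenyl on an amide-type nitrogen. Among the measured compounds shown here, the only measured step that touches this amide-type nitrogen, no change at the digits printed from compound 1 to compound 2 (within the scatter), stayed within the scatter, and no other measured step bears on the change. A step of the same kind, none beyond the scatter, is therefore expected here, a number 2 percentage points lower from compound 2 to compound 3 (within the scatter). Compound 3 is estimated at 70%, with a likely range from 55% to 85%.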

Compound 3, a percentage reported as inhibition, in the whole organism at one dose (the size of the read-out at that dose, not a potency): 50%
For compound 3 the middle estimate is 20 percentage points above the measured one, outside the stated range (below it).
By their numbers in this assay, from the lowest: compound 3; then compounds 1 and 2 (each within the scatter of the next).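

The amide-type nitrogen does not accept every aromatic group alike: in this assay, 4-hydroxyphenyl brings a number 22 percentage points lower from compound 2 to compound 3 (beyond the scatter) and a number 22 percentage points lower from compound 1 to compound 3 (beyond the scatter). A group on this nitrogen can therefore leave the inhibition unchanged, as 3-fluorophenyl does, or lower it, as 4-hydroxyphenyl does. Nothing measured here explains the drop.

The 3-fluorophenyl and 4-hydroxyphenyl groups differ both in what the ring carries and in where it carries it, so the two effects cannot yet be separated. A 3-hydroxyphenyl or 4-fluorophenyl group on this nitrogen would tell them apart.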